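Swapping fluoro for chloro on the anilide ring

A few compounds are considered here, and "the series" means these few. Any claim that something is new, unique, unknown or untested is made for them only; others in the source may bear on it.

Measured compounds in a functional assay on IGROV-1 cells (Homo sapiens) for cytotoxicity, read by sulforhodamine B assay, with a stated time of 48 h; a higher number here means a weaker inhibitor of growth, a lower number a stronger inhibitor of growth:
- compound 1 `CC1=C(C(=O)Nc2ccc(Cl)c(Cl)c2)C(c2cccc(O)c2)NC(=S)N1` gives 19100 nM
- compound 2 `CC1=C(C(=O)Nc2ccc(F)c(Cl)c2)C(c2cccc(Cl)c2)NC(=S)N1` gives 14100 nM
- compound 3 `CC1=C(C(=O)Nc2ccc(F)c(Cl)c2)C(c2cccc(Oc3ccccc3)c2)NC(=S)N1` gives 10700 nM

All three compounds share the same core and differ only in the two aryl groups that hang from it. Compound 3 has the lowest number of the three in this assay, but its gaps to compound 2 and to compound 1 both lie within the scatter, so the three cannot be ranked. Among the compounds with values here, the one single-point step that has been measured, a 1.3-fold lower number from compound 2 to compound 3 (0.12 log units; within the scatter), replaces a chloro with a phenoxy on the ring attached directly to the core and changes nothing beyond the scatter.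

Compound 4 `CC1=C(C(=O)Nc2ccc(Cl)c(Cl)c2)C(c2cccc(Oc3ccccc3)c2)NC(=S)N1` is the next compound. It differs from compound 3 in one place: chloro in place of fluoro on an aromatic carbon. Within the data shown here, no measured pair isolates this change. Compound 1 carries the same 3,4-dichlorophenyl amide but a different second ring, so its value and that of compound 3 speak to two changes at once, and they sit within the scatter of each other. Among the measured compounds shown here, both anilide variants therefore appear among compounds giving similar numbers, and no step so far has moved this assay beyond the scatter. The expected step is a 1.0-fold higher number from compound 3 to compound 4 (0.01 log units; within the scatter), that is, none beyond the scatter. For compound 4 the estimate is 11000 nM, with a range from 5000 nM to 25000 nM.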

Compound 4, concentration for 50% growth inhibition: 7760 nM
Beside the measured number, compound 4's estimate is 1.4-fold (0.15 log units) above it; the measured number falls inside the stated range.
By their numbers in this assay, from the lowest: compounds 4, 3, 2 and 1 (each within the scatter of the next, the first and the last beyond it).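

Replacing fluoro with chloro on the anilide ring, which turns 3-chloro-4-fluorophenyl into 3,4-dichlorophenyl, gives in this assay a 1.4-fold lower number from compound 3 to compound 4 (0.14 log units; within the scatter), so this first direct reading of the change shows no shift that can be told from the scatter. Within the data shown here, the more informative result comes from the ring attached directly to the core: with the 3,4-dichlorophenyl amide held fixed, putting a phenyl on the oxygen of the hydroxy group gives a 2.5-fold lower number from compound 1 to compound 4 (0.39 log units; beyond the scatter), the first step in this set to go beyond the scatter, though only modestly. Nothing available explains why this step is larger than the fluoro-to-chloro step.

Whether the phenoxy step would be repeated with the 3-chloro-4-fluorophenyl amide stays open, since the compounds shown include no hydroxy compound carrying that amide to pair with compound 3. Also open, from the compounds shown here alone, is how this assay would respond to a bromo group on the anilide ring, or to a methoxy group, an amine or a carboxylic acid in place of the phenoxy group.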